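From phenyl to methoxy: expected growth inhibition of compound 3

A few compounds are considered here, and "the series" means these few. Any claim that something is new, unique, unknown or untested is made for them only; others in the source may bear on it.

In a functional assay on NCI-H226 cells (Homo sapiens) for inhibition, read by sulforhodamine B assay, with a stated time of 48 h, tested at 10 uM (a lower number here means less inhibition of growth, a higher number more inhibition of growth at the concentration tested), compound 1 `CCOC(=O)c1ccc(Nc2ccnc(SCC(=O)c3ccc([N+](=O)[O-])cc3)n2)cc1` gives 16%.
In this assay, compound 2 `CC(=O)c1cccc(Nc2ccnc(SCC(=O)c3ccc(-c4ccccc4)cc3)n2)c1` gives 22%.

On these two numbers, compound 2 sits at the upper end, with compound 1 within the usual scatter of it, so the two cannot be told apart and neither can be called the more active. Both show only modest inhibition of growth at the single concentration tested.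

Compound 3 `COc1ccc(C(=O)CSc2nccc(Nc3cccc(C(C)=O)c3)n2)cc1` has not yet been measured in this assay. It differs from compound 2 in one place: methoxy in place of phenyl on an aromatic carbon. No measured pair with this same change exists among the compounds at hand, so the size of the step cannot be read off anything shown. With both measured compounds sitting close together at low inhibition, no step beyond the scatter is expected, and if anything a small movement downward.

For compound 3 the expected value in this assay is 18%, with a range from 5% to 35%. The step this estimate implies, a number 4 percentage points lower from compound 2 to compound 3 (within the scatter), is expected to remain within the scatter.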

Compound 3, percent growth inhibition at one concentration: 35%
Beside the measured number, compound 3's estimate is 17 percentage points below it; low and high end bracket the measured number.
By their numbers in this assay, from the lowest: compounds 1 and 2 (each within the scatter of the next); then compound 3.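

In this assay, methoxy in place of phenyl on an aromatic carbon, para to a large group, gives a number 13 percentage points higher from compound 2 to compound 3 (beyond the scatter), the first step among these compounds that rises above the scatter, and it shows that growth inhibition at this concentration responds to what this position carries. The phenyl ring is not required for that inhibition: methoxy, with 2 heavy atoms against 6 for phenyl and no ring, does not lower the read-out but raises it, though the change also brings in 1 hydrogen-bond acceptor, so the size of the group and the added oxygen change together. Nothing at hand bears on why the number moves upward.

The compounds shown leave open whether the gain follows the removal of the ring or the arrival of the oxygen, a question that a methyl group, a hydroxyl group or an ethoxy group on the same aromatic carbon would bear on. Compound 1 differs from compound 3 in more than one place, so its nitro group at this position cannot be weighed against methoxy.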